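Acyl variants on the threonine amide series: compound 4

This account rests on a few compounds, and the source may have more. Where it says the series, first, only, none or still open, it means among the compounds named here.

Working notes. The shared core carries a long alkyl amide on one side and an acyl amide on the other. In a functional assay on MCF7 cells (Homo sapiens) for cytotoxicity, read by MTT assay, with a stated time of 48 h (on this read-out higher numbers stand for weaker inhibition and lower numbers for stronger inhibition), compound 3 `CCCCCCCCCCCCNC(=O)[C@@H](NC(=O)c1cccs1)[C@@H](C)O` gives 30400 nM. Compound 2 `CCCCCCCCNC(=O)[C@@H](NC(=O)/C=C/c1ccccc1)[C@@H](C)O` gives 35100 nM, which sits within the scatter of compound 3. Compound 1 `CCCCCCCCNC(=O)[C@@H](NC(=O)c1cccs1)[C@@H](C)O` gives 72500 nM, beyond the scatter of both. Two single-point steps are known: a 2.1-fold lower number from compound 1 to compound 2 (0.32 log units; beyond the scatter) and a 2.4-fold lower number from compound 1 to compound 3 (0.38 log units; beyond the scatter).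

Compound 4 `C/C=C/C=C/C(=O)N[C@H](C(=O)NCCCCCCCCCCCC)[C@@H](C)O` differs from compound 3 as follows: penta-1,3-dien-1-yl in place of thiophen-2-yl on a carbonyl carbon. The step that bears on this is the swap on the carbonyl carbon from thiophen-2-yl to the open, doubly unsaturated 2-phenylethenyl, which gave a 2.1-fold lower number from compound 1 to compound 2 (0.32 log units; beyond the scatter). The incoming penta-1,3-dien-1-yl is likewise an open chain with two double bonds outside aromatic rings and no ring. A modest lowering of the number, or none beyond the scatter, is therefore expected; the step from compound 3 to compound 4 is estimated as a 1.5-fold lower number from compound 3 to compound 4 (0.18 log units; within the scatter). For compound 4 the expected value in this assay is 20000 nM, with a range from 8000 nM to 50000 nM.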

Compound 4, half-maximal inhibitory concentration: 37100 nM
The estimate for compound 4 lay 1.9-fold (0.27 log units) below the measured number; measured number inside the range.
By their numbers in this assay, from the lowest: compounds 3, 2, 4 and 1 (each within the scatter of the next, the first and the last beyond it).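

In this assay, a 1.2-fold higher number from compound 3 to compound 4 (0.09 log units; within the scatter) shows that on the longer amide chain, the carbonyl carbon accepts an open chain with 2 double bonds outside aromatic rings in place of the five-membered aromatic ring and its sulfur, with no change beyond the scatter. The earlier change on this carbonyl carbon, a 2.1-fold lower number from compound 1 to compound 2 (0.32 log units; beyond the scatter), brought in a different group on a different amide chain, so the two steps cannot be read as one effect. Nothing at hand gives a measured reason for this result.

From the compounds shown here alone, it remains open whether penta-1,3-dien-1-yl would give the same kind of step on the amide chain of compound 1. Also open, going by these compounds, is how a saturated pentyl chain or an amine-bearing chain on this carbonyl carbon would read in this assay.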